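This account rests on a few compounds, and the source may have more. Where it says the series, first, only, none or still open, it means among the compounds named here.

Measured compounds:
compound 1 `CCC1=C(O)c2c(oc(-c3ccc(C(F)(F)F)cc3)cc2=O)C(CC)(CC)C1=O`: 10.4 uM
compound 2 `CCC1=C(O)c2c(oc(-c3ccc(OC)cc3)cc2=O)C(CC)(CC)C1=O`: 0.68 uM
compound 3 `CCC1=C(O)c2c(oc(-c3cccc(C(F)(F)F)c3)cc2=O)C(CC)(CC)C1=O`: 5.42 uM

All three were run in a functional assay on KBVIN cells (Homo sapiens) for antiproliferative activity, read by sulforhodamine B assay, with a stated time of 3 days; a higher number here means that more compound is needed for the effect, a lower number that less compound is needed. Compound 1 and compound 3 share the same atoms joined differently; the difference between the two cores is not broken down here. Compound 2 differs from compound 1 by methoxy in place of trifluoromethyl on an aromatic carbon, and that change gave a 15-fold lower number from compound 1 to compound 2 (1.18 log units; beyond the scatter).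

Compound 4 `CCC1=C(O)c2c(oc(-c3cccc(OC)c3)cc2=O)C(CC)(CC)C1=O` is not yet measured in this assay. It differs from compound 3 by methoxy in place of trifluoromethyl on an aromatic carbon. This is the same kind of change as from compound 1 to compound 2, though the place is not identical: in the earlier pair the group sits para to a large group, here meta to a large group. Compound 3 gives a number in this assay near that of compound 1, within the scatter, so the starting points are comparable.

For the measured compounds named here, on that basis a step of the same direction is expected, an 11-fold lower number from compound 3 to compound 4 (1.04 log units; beyond the scatter), resting on the one earlier step from compound 1 to compound 2 and on compound 3 giving 5.42 uM. The estimate for compound 4 in this assay is 0.5 uM, expected between 0.15 uM and 1.6 uM.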

Compound 4, concentration for half-maximal effect: 1.22 uM
Compound 4: middle estimate off by 2.4-fold (0.39 log units), on the low side; measured number inside the range.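

In this assay, methoxy in place of trifluoromethyl moves the number the same way on both cores, but the size of the step does not carry over: the same change on two cores in this assay, a 15-fold lower number (1.18 log units; beyond the scatter) from compound 1 to compound 2 and a 4.4-fold lower number (0.65 log units; beyond the scatter) from compound 3 to compound 4, 3.4-fold (0.54 log units) apart, beyond the scatter of two such steps

The direction therefore holds across this one pair of cores, while the size has to be treated as dependent on the core: the step of a 4.4-fold lower number from compound 3 to compound 4 (0.65 log units; beyond the scatter) cannot be predicted by transferring the earlier step unchanged. Moving the methoxy group, 3-methoxyphenyl in place of 4-methoxyphenyl, gives a 1.8-fold higher number from compound 2 to compound 4 (0.25 log units; within the scatter), so the two methoxy compounds cannot be told apart here; with only two pairs, these data do not show why the steps differ or whether the direction would hold on any further core.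

On these data alone, whether the same ring positions tolerate an amine, a carboxylic acid or a longer chain such as ethoxy remains open. Also open, as far as these compounds go, is whether the difference between the two steps would persist with any group other than methoxy replacing trifluoromethyl.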